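From compound 3 to compound 4: a sulfonyl group swap

A few compounds are considered here, and "the series" means these few. Any claim that something is new, unique, unknown or untested is made for them only; others in the source may bear on it.

Measured so far, all limits:
- compound 1 `COc1ccc(-c2c(C)nc3c(N4CC[C@@H](NC(=O)OC5CCCCC5)C4)cc(C)nn23)cc1OC` gives > 95%
- compound 2 `COc1ccc(-c2c(C)nc3c(N4CC[C@@H](NS(=O)(=O)c5ccc(Cl)cc5)C4)cc(C)nn23)cc1OC` gives > 95%
- compound 3 `COc1ccc(-c2c(C)nc3c(N4CC[C@@H](NS(=O)(=O)c5ccc(C(F)(F)F)cc5)C4)cc(C)nn23)cc1OC` gives > 95%

In an ADME assay on microsomes from liver (Mus musculus) for metabolic stability, read by LC-MS, with NADPH named in the record, with a stated time of 60 min, tested at 1 uM, in the absence of a further agent (on this read-out higher numbers stand for a more stable compound and lower numbers for a less stable compound), compound 3 gives > 95% as a limit and not a number. All the measured compounds share the limit of > 95% in this assay, at which 3 of the 3 values shown sit, and no order among them can be read. The next compound is compound 4 `COc1ccc(-c2c(C)nc3c(N4CC[C@@H](NS(=O)(=O)c5cccs5)C4)cc(C)nn23)cc1OC` with thiophen-2-yl in place of 4-(trifluoromethyl)phenyl on a sulfonyl sulfur in the structure. The measured steps bearing on it are a step that the two limits leave unreadable from compound 1 to compound 2 and a step that the two limits leave unreadable from compound 2 to compound 3 and neither has a readable size. The estimated a number at least 3 percentage points lower from compound 3 to compound 4 (that floor lies within the scatter) is a slight loss in this assay and is not expected to pass the scatter. Compound 4 is estimated at 92% with an expected range from 78% to 100% for the measurement.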

Compound 4, percent of the compound remaining: > 95%
Compound 4: no number, only a limit; the forecaster's own chance of this, stated with the estimate: 55%; middle value at least 3 percentage points from the limit.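

Compound 4 gives > 95% in this assay, a limit and not a number. For the compounds shown here, no step from compound 1, compound 2 or compound 3 to compound 4 can be read: the limit of > 95% in this assay, at which 4 of the 4 values shown sit. The compounds shown leave open whether any of these swaps changes stability at all.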